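Nitro in Place of Chloro: Expecting No Shift

This account rests on a few compounds, and the source may have more. Where it says the series, first, only, none or still open, it means among the compounds named here.

Compound 1 `C=C(C)[C@@H]1CC=C(C)/C(=N/NC(=O)Nc2nnc(-c3ccc(F)cc3)o2)C1`: 100 mg/kg
Compound 2 `C=C(C)[C@@H]1CC=C(C)/C(=N/NC(=O)Nc2nnc(-c3ccc(O)cc3)o2)C1`: 100 mg/kg
Compound 3 `CC(C)=CC/C=C(/C)C/C=N/NC(=O)Nc1nnc(-c2ccc(Cl)cc2)o1`: 100 mg/kg

The three measured compounds were tested in a functional assay on the whole organism (strain Swiss albino) with Mus musculus as the target, with a stated time of 0.5 h; a higher number here means that more compound is needed for the effect, a lower number that less compound is needed. Compound 1 gives 100 mg/kg, compound 2 gives 100 mg/kg and compound 3 gives 100 mg/kg. Compound 3 therefore stands level with compounds 1 and 2 at the digits shown; none of the three can be called stronger or weaker than another.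

Compound 4 `CC(C)=CC/C=C(/C)C/C=N/NC(=O)Nc1nnc(-c2ccc([N+](=O)[O-])cc2)o1` is not yet measured. It differs from compound 3 in one place: nitro in place of chloro on an aromatic carbon.

Going by the values given here, the only measured step that bears on this change is the one on the same aromatic carbon of the shared core, no change at the digits printed from compound 1 to compound 2 (within the scatter), where one group was swapped for another and the readout did not move. Compound 3 itself, carrying chloro, sits at the same value as compounds 1 and 2. With every substituent tried at this place giving the same number, the replacement of chloro by nitro is expected to bring no step beyond the scatter, so compound 4 is estimated to show no change at the digits printed from compound 3 to compound 4 (within the scatter).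

Compound 4 is accordingly expected to give about 100 mg/kg, within a range from 50 mg/kg to 200 mg/kg.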

Compound 4, minimum effective dose: 100 mg/kg
Beside the measured number, compound 4's estimate shows no gap at the digits printed, and the stated range covers the measured number.
By their numbers in this assay, from the lowest: compounds 1, 2, 3 and 4 (each within the scatter of the next).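

In this assay, going by these compounds alone, the change from 4-chlorophenyl to 4-nitrophenyl gives no change at the digits printed from compound 3 to compound 4 (within the scatter), so the core of compound 3 now has a step of its own at this aromatic carbon, where the earlier compounds offered only the step on the core of compound 1, no change at the digits printed from compound 1 to compound 2 (within the scatter). The new step also shows that a larger entering group, nitro with its three heavy atoms and two hydrogen-bond acceptors in place of the single heavy atom and no acceptors of chloro, produces no step beyond the scatter on this core. Nothing among the data shown accounts for this flat result.

Since all four compounds share one value, they leave open whether any group at this carbon can shift the minimum effective dose, a question that an amine, a carboxylic acid or a longer chain there could address. The compounds shown also include no pair that carries the same substituent on both cores, so what each core contributes to the dose remains unread.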